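The compounds below may be only part of what the source reports. "The series", "measured", "known", "first", "only" and "open" are said of these compounds alone.

Measured so far:
Compound 1, `CCCOc1ccc(C(C)=O)cc1NC(=O)c1cccc(C(=O)O)c1`: 3.4 degrees C
Compound 2, `CC(=O)c1ccc(OCC(C)C)c(NC(=O)c2cccc(C(=O)O)c2)c1`: 3 degrees C

In an assay on isolated protein for binding affinity to histone acetyltransferase p300 (Homo sapiens), read by thermal shift assay, tested at 100 uM (a higher number here means that the compound stabilises the target more against heat, a lower number that the compound stabilises the target less), compound 2 gives 3 degrees C, the smaller of the two numbers shown, yet the step of a number 0.40 degrees C lower from compound 1 to compound 2 (within the scatter) means the two compounds cannot be told apart. Compound 3, `CC(=O)c1ccc(OCC2CC2)c(NC(=O)c2cccc(C(=O)O)c2)c1`, differs from compound 2 by cyclopropyl in place of isopropyl on a saturated chain carbon bound to an oxygen on an aromatic ring. For the measured compounds named here, only one measured step bears on this: a number 0.40 degrees C lower from compound 1 to compound 2 (within the scatter), which also altered the same chain and moved nothing beyond the scatter. The change to compound 3 is therefore expected to be small, no change at the digits printed from compound 2 to compound 3 (within the scatter). Compound 3 is estimated at 3 degrees C, ranging from 2 degrees C to 4 degrees C.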

Compound 3, shift of the target's melting temperature: 3.6 degrees C
Compound 3: middle estimate off by 0.60 degrees C, on the low side, within the range that was stated.
By their numbers in this assay, from the lowest: compounds 2, 1 and 3 (each within the scatter of the next).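

In this assay, putting cyclopropyl in place of isopropyl gives a number 0.60 degrees C higher from compound 2 to compound 3 (within the scatter), and putting it in place of ethyl gives a number 0.20 degrees C higher from compound 1 to compound 3 (within the scatter). For the compounds shown here, a three-membered ring can therefore stand on this saturated chain carbon, where the earlier compounds carried only open chains, with no step beyond the scatter. No measurement shown here offers an explanation for these numbers. Still open, on these data alone, is whether an amine, a carboxylic acid or a longer chain at this place would move the number beyond the scatter.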